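Liver microsome stability: trifluoromethyl for cyano on the pyridine

The source may report more compounds than this note shows. Statements on the series, on what has been measured and on what is new or still open speak of the compounds shown alone.

Of the compounds shown here, two have been measured in an ADME assay on microsomes from liver (Mus musculus) for metabolic stability, read by LC-MS, using NADPH, with a stated time of 10 min, tested at 10 uM; a lower number here means that the compound disappears faster, a higher number that the compound lasts longer. Compound 1 `Nc1ncnc2c1c(Oc1cccc(C(F)(F)F)c1)nn2[C@H]1C[C@H](O)C1` gives 0.367 h. Compound 2 `N#Cc1ccnc(Oc2nn(C3CCC3)c3ncnc(N)c23)c1` gives 0.4 h, and the two numbers lie within the usual scatter of each other, so neither stands apart. Compound 3 `Nc1ncnc2c1c(Oc1cc(C(F)(F)F)ccn1)nn2C1CCC1` is not yet measured; it differs from compound 2 by trifluoromethyl in place of cyano on an aromatic carbon. Among the compounds with values here, no step between measured compounds of this kind exists here. Both measured numbers are low and alike, so compound 3 is expected to stay close to compound 2, with a step of a 1.1-fold lower number from compound 2 to compound 3 (0.06 log units; within the scatter) that should not exceed the scatter. The estimate for compound 3 in this assay is 0.35 h, ranging from 0.18 h to 0.7 h.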

Compound 3, half-life: 0.128 h
The estimate for compound 3 lay 2.7-fold (0.44 log units) above the measured number, outside the stated range (below it).
By their numbers in this assay, from the lowest: compound 3; then compounds 1 and 2 (each within the scatter of the next).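

In this assay, trifluoromethyl in place of cyano on the aromatic carbon opposite the ring nitrogen gives a 3.1-fold lower number from compound 2 to compound 3 (0.49 log units; beyond the scatter) and so counts as a modest step. The group on this carbon therefore matters to the read-out, which compounds 1 and 2 could not show, as they differ in more than one place. Nothing at hand bears on the reason for this step. Open, as far as these compounds go, is whether an amine or a methoxy group on this carbon would sit nearer compound 2 or compound 3, and whether the same exchange gives a similar step with another group on the shared core.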